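The source may hold more compounds than are shown below. What is called first, only, known or untested is meant among the compounds shown, and "the series" means these compounds.

Measured so far:
compound 1, `CC(=O)OC(C)n1cnc2c(Cl)nc(I)nc21`: 14500 nM
compound 2, `CC(=O)OC(C)n1cnc2c(Cl)nc(F)nc21`: 93300 nM

Both compounds were tested in a functional assay (Homo sapiens) for inhibition; a lower number here means a stronger inhibitor, a higher number a weaker inhibitor. Compound 1 gives 14500 nM, and compound 2 gives 93300 nM, the higher of the two numbers. Among the compounds with values here, the one step between them, a 6.4-fold higher number from compound 1 to compound 2 (0.81 log units; beyond the scatter), comes from a fluoro in place of iodo on an aromatic carbon. Compound 3, `CC(=O)OC(C)n1cnc2c(S)nc(F)nc21`, differs from compound 2 in another way: sulfanyl in place of chloro on an aromatic carbon. Within the data shown here, no measured step bears on this change; the only step recorded, a 6.4-fold higher number from compound 1 to compound 2 (0.81 log units; beyond the scatter), swaps one halogen for another and gives no guide to the exchange of chloro for sulfanyl. With nothing pointing either way, the number for compound 3 in this assay is expected to stay near that of compound 2, and the step of a 1.3-fold lower number from compound 2 to compound 3 (0.12 log units; within the scatter) is expected to lie within the scatter. The estimate for compound 3 is 70000 nM, between 15000 nM and 300000 nM.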

Compound 3, half-maximal inhibitory concentration: > 500000 nM
Compound 3: only a limit was reported (the forecaster's own chance of this, stated with the estimate: 30%); at least 7.1-fold (0.85 log units) between middle value and limit.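

In this assay compound 3 gives a limit, not a number: the limit of > 500000 nM in this assay, at which 1 of the 3 values shown sits. The earlier pair showed only that exchanging iodo for fluoro changes the result, and both of those compounds kept the chloro group and gave measurable numbers. The step for sulfanyl in place of chloro, on the aromatic carbon meta to a fluoro group, is an at least 5.3-fold higher number from compound 2 to compound 3 (0.72 log units; beyond the scatter) and shows that this second position also matters, since this exchange gives a weaker inhibitor.

From the compounds shown here alone, it remains open whether the loss of chloro or the arrival of sulfanyl drives this step, and a bromo group or an amine at the same carbon could help separate the two. Going by these compounds, it is also open whether iodo in place of fluoro would change the outcome with sulfanyl present.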